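Lengthening the chain from compound 3 to compound 4

The source may hold more compounds than are shown below. What is called first, only, known or untested is meant among the compounds shown, and "the series" means these compounds.

In a functional assay on A549 cells (Homo sapiens) for antiproliferative activity, read by MTT assay, with a stated time of 48 h (a lower number here means a stronger inhibitor, a higher number a weaker inhibitor), compound 1 `COc1ccc(N(C)c2ccnc(Cl)n2)cc1O` gives 381 nM, compound 2 `COc1ccc(N(C)c2ccnc(Cl)n2)cc1OCC[Se]C#N` gives 463 nM, and compound 3 `COc1ccc(N(C)c2ccnc(Cl)n2)cc1OCCC[Se]C#N` gives 3710 nM, the highest number of the three. Compound 4 `COc1ccc(N(C)c2ccnc(Cl)n2)cc1OCCCCC[Se]C#N` differs from compound 3 by a group of 5 heavy atoms (3 carbon, 1 nitrogen, 1 selenium; no ring) in place of a group of 3 heavy atoms (1 carbon, 1 nitrogen, 1 selenium; no ring), on a saturated chain carbon, three bonds along the chain from an oxygen on an aromatic ring. Going by the values given here, the nearest precedent is the single chain change measured so far, an 8.0-fold higher number from compound 2 to compound 3 (0.90 log units; beyond the scatter). Also relevant are a 1.2-fold higher number from compound 1 to compound 2 (0.08 log units; within the scatter) and a 9.7-fold higher number from compound 1 to compound 3 (0.99 log units; beyond the scatter). Among the compounds with values here, with only one such chain step available, a further rise in this assay is expected, smaller than that step and poorly defined. The expected change is a 2.2-fold higher number from compound 3 to compound 4 (0.33 log units; beyond the scatter). Compound 4 is estimated at 8000 nM, with an expected range of 1500 nM to 30000 nM.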

Compound 4, half-maximal inhibitory concentration: > 10000 nM
Compound 4 was reported as a limit; the forecaster's own chance of this, stated with the estimate: 8%; at least 1.2-fold (0.09 log units) between middle value and limit.
By their numbers in this assay, from the lowest: compounds 1 and 2 (each within the scatter of the next); then compound 3. At a limit, above all of these: compound 4.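

Compound 4 is reported only as a limit in this assay: the limit of > 10000 nM in this assay, at which 1 of the 4 values shown sits. Lengthening the chain further gives an at least 2.6-fold higher number from compound 3 to compound 4 (0.43 log units; beyond the scatter), so the rise does not stop at compound 3, and the overall chain change gives an at least 21-fold higher number from compound 2 to compound 4 (1.33 log units; beyond the scatter). Replacing the hydrogen on the aromatic oxygen with this longest chain gives an at least 26-fold higher number from compound 1 to compound 4 (1.41 log units; beyond the scatter), whereas compound 2, with the shortest chain shown, stays within the scatter of compound 1.

As far as these compounds go, the true size of these steps remains open while compound 4 stands at a limit. From the compounds shown here alone, whether an amine or a carboxylic acid at the chain end would change this trend also remains open.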